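The compounds below may be only part of what the source reports. "The series", "measured", "known", "first", "only" and "open" are said of these compounds alone.

Compound 2, with structure `Cc1ccc(C(=O)Nc2nc(-c3ccccc3)cn3cc(-c4ccccc4)nc23)cc1`, is the one on which the next step rests. Among the measured compounds shown here, in an assay on cells for displacement of a labelled ligand from adenosine receptor A1 (Homo sapiens), read by scintillation counting, with a stated time of 120 min, tested at 1 uM (a higher number here means more inhibition at the concentration tested (going by the name of the read-out), a lower number less inhibition), compound 2 gives 1%, the lowest of the two numbers so far, and its nearest neighbour is compound 1 with structure `COc1ccc(C(=O)Nc2nc(-c3ccccc3)cn3cc(-c4ccccc4)nc23)cc1`, which in this assay gives 6%. For the measured compounds named here, the only measured step, a number 5 percentage points lower from compound 1 to compound 2 (within the scatter), came from swapping one small group for another on the same aromatic carbon and stayed within the scatter. The compound not yet measured is compound 3, with structure `O=C(Nc1nc(-c2ccccc2)cn2cc(-c3ccccc3)nc12)c1ccc(F)cc1`; relative to compound 2 the change is fluoro in place of methyl on an aromatic carbon. Going by the values given here, that step has a bearing from the earlier one only in that it touches the same carbon of the same ring; no measured step involves fluoro. Both measured numbers sit at the floor of the read-out, so the expectation for compound 3 is no step beyond the scatter, a number 2 percentage points higher from compound 2 to compound 3 (within the scatter). The estimate for compound 3 is 3%, expected between 0% and 12%.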

Compound 3, a percentage reported as inhibition, at one concentration (the size of the read-out at that concentration, not a potency): 1%
The estimate for compound 3 lay 2 percentage points above the measured number; the measured number falls inside the stated range.
By their numbers in this assay, from the lowest: compounds 2, 3 and 1 (each within the scatter of the next).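

In this assay a third group on this same aromatic carbon, para to a large group, gives a reading that cannot be told apart from the other two: the change to fluoro leaves no change at the digits printed from compound 2 to compound 3 (within the scatter) and gives a number 5 percentage points lower from compound 1 to compound 3 (within the scatter) when set against methoxy. Methyl, methoxy and fluoro are thus all equally without visible effect here, so this small swap adds a third flat reading where the earlier pair offered only one step. No measurement at hand offers any explanation for this flat result.

Still open, going by these compounds, is whether a larger or charged group at this carbon, such as an amine, a carboxylic acid or a longer alkyl chain, would move the number beyond the scatter. Also open, on these data alone, is whether changes elsewhere on the shared core would do so.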